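The compounds below may be only part of what the source reports. "The series", "measured", "known", "first", "only" and "open" are said of these compounds alone.

Compound 1 `COc1cc(-c2nn(-c3cccc(NC(=O)c4ccc(Cl)c(C(F)(F)F)c4)c3)cc2-c2ccncc2)ccc1Cl` has been tested in a functional assay on OVCAR-4 cells (Homo sapiens) for inhibition, read by sulforhodamine B assay, with a stated time of 48 h; a lower number here means a stronger inhibitor of growth, a higher number a weaker inhibitor of growth. In this assay compound 1 gives > 32500 nM, which is a limit of the measurement and not a number. Where compound 1 stands on the numbers shown is therefore known only from one side: the limit of > 32500 nM in this assay, at which 1 of the 2 values shown sits. The other measured compound is compound 2 `O=C(Nc1cccc(-n2cc(-c3ccncc3)c(-c3ccc(Cl)c(O)c3)n2)c1)Nc1cc(C(F)(F)F)cc(C(F)(F)F)c1`, and in this assay compound 2 gives 5010 nM. Compound 2 differs from compound 1 in more than one place, so its value only shows that one structure of this family reaches a measurable concentration while compound 1 stays at its limit.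

The unmeasured compound 3 `COc1cc(-c2nn(-c3cccc(NC(=O)Nc4ccc(Cl)c(C(F)(F)F)c4)c3)cc2-c2ccncc2)ccc1Cl` differs from compound 1 by the change ((4-chloro-3-(trifluoromethyl)phenyl)amino in place of 4-chloro-3-(trifluoromethyl)phenyl on a carbonyl carbon). For the measured compounds named here, no pair of measured compounds that differ in a single place is available, so the size of this kind of step has not been observed here, and since compound 1 sits at a limit any step can only be estimated. The step from compound 1 to compound 3 in this assay is expected to be an at least 2.1-fold lower number from compound 1 to compound 3 (0.33 log units; beyond the scatter), toward stronger inhibition, with a fair chance of landing at the limit again. Compound 3 is expected to give about 15000 nM, within 3000 nM to 40000 nM.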

Compound 3, concentration for total growth inhibition: 25600 nM
Compound 3: middle estimate off by 1.7-fold (0.23 log units), on the low side, within the range that was stated.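

For the compounds shown here, compound 3 gives the first comparison in this family that differs in only one place: on the carbonyl carbon, (4-chloro-3-(trifluoromethyl)phenyl)amino replaces 4-chloro-3-(trifluoromethyl)phenyl, and with this change a measured concentration is reached in this assay. The size of the change can be stated only as a floor, an at least 1.2-fold lower number from compound 1 to compound 3 (0.10 log units; that floor lies within the scatter), so this single pair does not establish a real difference, though the true step may be larger. Compound 1 stands at a limit and not at a number, so the step is bounded from one side only: the limit of > 32500 nM in this assay, at which 1 of the 3 values shown sits.

On these data alone, whether the new nitrogen with its hydrogen matters, or simply the longer link to the chlorinated ring, stays open, and a methylene group or a methyl-substituted nitrogen in the same place would help separate these two readings. As far as these compounds go, compound 2 differs from compound 3 in more than one place, so its value cannot be assigned to any single change, and the effect of this replacement on other members of the family remains unknown.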